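The source may report more compounds than this note shows. Statements on the series, on what has been measured and on what is new or still open speak of the compounds shown alone.

Measured so far:
- compound 1 `CCOCc1nc(Nc2ccc(C(F)(F)F)cc2)c2ccc(-c3ncccc3C(F)(F)F)cc2n1`: 0.9 nM
- compound 2 `CS(=O)(=O)CCc1nc(Nc2ccc(C(F)(F)F)cc2)c2ccc(-c3ncccc3C(F)(F)F)cc2n1`: 36 nM

In a functional assay for antagonist activity at transient receptor potential cation channel subfamily V member 1 (Homo sapiens) (a lower number here means a stronger inhibitor, a higher number a weaker inhibitor), compound 1 gives the lowest of the two numbers; its nearest neighbour is compound 2, reached by a 40-fold higher number from compound 1 to compound 2 (1.60 log units; beyond the scatter). Compound 3 `FC(F)(F)c1ccc(Nc2nc(CNC3CCCCC3)nc3cc(-c4ncccc4C(F)(F)F)ccc23)cc1` is not yet measured. Its difference from compound 1: cyclohexylamino in place of ethoxy on a saturated chain carbon bound to an aromatic carbon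

For the measured compounds named here, the one measured step at this position is the move from compound 1 to compound 2, and it was large and upward. Compound 3 changes the same place, so a step upward in this assay is expected, though its size is uncertain. The estimated step is an 11-fold higher number from compound 1 to compound 3 (1.05 log units; beyond the scatter). For compound 3 the expected value is 10 nM, within 2 nM to 60 nM.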

Compound 3, half-maximal inhibitory concentration: 6 nM
Estimate against measurement, compound 3: 1.7-fold (0.22 log units) above; the range from low to high includes it.
By their numbers in this assay, from the lowest: compound 1; then compound 3; then compound 2.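

In this assay, cyclohexylamino on the saturated chain carbon gives a 6.7-fold higher number from compound 1 to compound 3 (0.82 log units; beyond the scatter), so ethoxy remains ahead. Against the sulfone, the same group gives a 6.0-fold lower number from compound 2 to compound 3 (0.78 log units; beyond the scatter), which shows that the loss from ethoxy depends on the group that replaces it and that this position still holds up with a six-membered non-aromatic ring and a hydrogen-bond donor in place. No measurement at hand accounts for this order.

Cyclohexyloxy would separate the contribution of the ring from that of the nitrogen. On these data alone, whether a smaller amine such as dimethylamino comes closer to compound 1 also remains open.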